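The source may report more compounds than this note shows. Statements on the series, on what has been measured and on what is new or still open speak of the compounds shown alone.

Measured in a functional assay on DU-145 cells (Homo sapiens) for antiproliferative activity, read by MTT assay, with a stated time of 72 h; on this read-out higher numbers stand for weaker inhibition and lower numbers for stronger inhibition:
- Compound 1 `O=C(COc1ccc(C(=O)/C=C/c2cccc(Cl)c2)cc1)N[C@H]1CCOC1=O`: 3700 nM
- Compound 2 `Cc1ccc(C(C)C)c(OCCSC(=S)N[C@H]2CCOC2=O)c1`: > 64000 nM

Among the compounds with values here, compound 1 holds the only true number in this small set, so it is the sole firm reference point, at 3700 nM. For compound 2, the entry > 64000 nM is a limit of the assay and not a number.

The next compound, compound 3 `O=C(COc1ccc(C(=O)/C=C/c2ccc(F)cc2)cc1)N[C@H]1CCOC1=O`, keeps the core of compound 1 and carries 4-fluorophenyl in place of 3-chlorophenyl on a double-bonded chain carbon bound to a double-bonded chain carbon. Within the data shown here, no measured pair shows what such a swap does in this assay, so this expectation is a cautious one. The expected change is a 1.1-fold higher number from compound 1 to compound 3 (0.03 log units; within the scatter), which means no step beyond the usual scatter. Compound 3 is estimated at 4000 nM, with an expected range of 1500 nM to 11000 nM.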

Compound 3, half-maximal inhibitory concentration: 18800 nM
For compound 3 the middle estimate is 4.7-fold (0.67 log units) below the measured one; measured number above the stated range.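

Swapping 3-chlorophenyl for 4-fluorophenyl on a double-bonded chain carbon bound to a double-bonded chain carbon gives, in this assay, a 5.1-fold higher number from compound 1 to compound 3 (0.71 log units; beyond the scatter). Within the data shown here, this is the first evidence in the set that this position matters: with the rest of the molecule unchanged, the substituted phenyl ring alone shifts the result beyond the usual scatter, although this rests on a single pair. The swap changes both the halogen and its place on the ring, and nothing shown here explains why the number rises.

As far as these compounds go, it remains open whether the halogen or its place on the ring drives the step, a question that 3-fluorophenyl and 4-chlorophenyl would help to separate. Plain phenyl would show how either halogen compares with none.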